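This account rests on a few compounds, and the source may have more. Where it says the series, first, only, none or still open, it means among the compounds named here.

Measured compounds:
Compound 1 `CO/C(O)=C(/C=N/c1ccc(Oc2ccccc2OC(C)C)nc1)NC(=O)c1ccccc1` gives 8% in a functional assay on RPTEC cells (Homo sapiens), tested at 10 uM; a lower number here means less inhibition, a higher number more inhibition at the concentration tested (going by the name of the read-out).
Compound 2 `Cc1c(Cc2c(Cl)cccc2Cl)c(=O)oc2cc(OCC(=O)OCC(=O)c3ccc(Cl)cc3)ccc12` gives 21% in this assay.

Compound 2 stands highest of the two numbers recorded in this assay. Its nearest neighbour is compound 1, whose value lies lower by a gap that goes beyond the usual scatter of repeated measurements, so compound 2 shows more inhibition than compound 1 at the concentration tested. Among the compounds with values here, the two compounds share no common core, and no step between them is set out; their two values are all that can be said of the pair.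

Compound 3 `Cc1c(Cc2c(Cl)cccc2Cl)c(=O)oc2cc(OCC(=O)OCC(=O)c3ccccc3)ccc12` has not yet been measured. It differs from compound 2 in one place: hydrogen in place of chloro on an aromatic carbon. Within the data shown here, no step between measured compounds is available for this kind of change, so the expectation rests on the value of compound 2 alone. Because compound 2 gives 21%, a modest starting point, the step of a number 4 percentage points lower from compound 2 to compound 3 (within the scatter) is expected to be small, most likely within the scatter, with a slight lean toward less inhibition. Compound 3 is therefore estimated at 17%, with a range from 5% to 30%.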

Compound 3, a percentage reported as inhibition, at one concentration (the size of the read-out at that concentration, not a potency): 31%
Compound 3: the middle estimate sits 14 percentage points below what was measured; measured number outside the range, above it.
By their numbers in this assay, from the lowest: compound 1; then compounds 2 and 3 (each within the scatter of the next).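

In this assay, hydrogen in place of chloro on an aromatic carbon, para to a large group, gives the first step that can be read among these compounds: a number 10 percentage points higher from compound 2 to compound 3 (within the scatter). Within the data shown here, this is the first comparison of two compounds that differ in one place, and it shows that taking 4-chlorophenyl to phenyl leaves the two compounds within the scatter of each other, so the chloro is not required for the inhibition seen at the concentration tested. No measurement shown here speaks to the reason for this result.

With only chloro and hydrogen shown at this position, it remains open whether another group there, such as a methoxy, an amine or a carboxylic acid, would produce a step beyond the scatter. From the compounds shown here alone, it is also open whether a longer chain in place of benzoylmethyl, or the same change from chloro to hydrogen on the other aromatic ring that carries chloro, would leave the number in this assay within the scatter as well.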